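The source may hold more compounds than are shown below. What is called first, only, known or untested is meant among the compounds shown, and "the series" means these compounds.

Working notes on the series.

Compound 1 `CC1(C)C=C(n2ccccc2=O)c2cc(S(=O)(=O)N=[N+]=[N-])ccc2O1` is the reference point: in a functional assay on the whole organism (trachea) with Rattus norvegicus as the target (on this read-out lower numbers stand for smaller maximal responses and higher numbers for larger maximal responses), compound 1 gives 77.2%. For the measured compounds named here, compound 2 `CC1(C)C=C(n2ccccc2=O)c2cc(S(=O)(=O)NC(=O)Nc3ccccc3)ccc2O1` carries a (phenylcarbamoyl)amino in place of the azido on the sulfonyl sulfur, and in this assay compound 2 gives 99.5%, the highest of the two numbers so far; the step of a number 22.3 percentage points higher from compound 1 to compound 2 (beyond the scatter) is the only measured step to draw on.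

Compound 3 `CC1(C)C=C(n2ccccc2=O)c2cc(S(=O)(=O)c3ccccc3)ccc2O1` is the next point. Its change from compound 2 is phenyl in place of (phenylcarbamoyl)amino on a sulfonyl sulfur. Going by the values given here, the one measured step concerns the same sulfonyl sulfur and shows that what sits there can move the maximal response by a modest amount; it does not show the direction for a phenyl, and neither measured compound carries one. The expectation for compound 3 is therefore a number lying between those of the two measured compounds, with the step of a number 11.5 percentage points lower from compound 2 to compound 3 (beyond the scatter) expected to stay close to the scatter. Compound 3 is estimated at 88%, within 70% to 100%.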

Compound 3, largest response reached (Emax), in percent of the reference or control that the assay uses: 88.1%
For compound 3 the middle estimate is 0.1 percentage points below the measured one, within the range that was stated.
By their numbers in this assay, from the lowest: compound 1; then compound 3; then compound 2.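

Phenyl in place of (phenylcarbamoyl)amino on the sulfonyl sulfur gives a number 11.4 percentage points lower from compound 2 to compound 3 (beyond the scatter), while phenyl in place of azido gives a number 10.9 percentage points higher from compound 1 to compound 3 (beyond the scatter). The three groups at this place therefore give three separate levels in this assay, and the hydrogen-bond donors counted for (phenylcarbamoyl)amino can be absent without the number returning to that of compound 1. Nothing available accounts for these differences.

For the compounds shown here, with only three groups compared, it remains open which part of (phenylcarbamoyl)amino goes with the higher number in compound 2, since the phenyl of compound 3 differs from it in several features at once. A simple amine, a methyl or a benzyl on the sulfonyl sulfur would show whether the order of the three compounds extends to other groups.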